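Varying the ethoxycarbonyl group: ethyl to 2,2,2-trichloroethyl

A few compounds are considered here, and "the series" means these few. Any claim that something is new, unique, unknown or untested is made for them only; others in the source may bear on it.

Three compounds share one core and differ only in the group on the oxygen next to a carbonyl group. Compound 1 `CCOC(=O)N1CCN(C(=O)c2nc(Nc3cc(C4CC4)[nH]n3)c3cc(Cl)ccc3n2)C[C@H]1C` carries ethyl there; in an assay for inhibition of serine/threonine-protein kinase PAK 4 (Homo sapiens), read by FRET and Z'-LYTE, with a stated time of 60 min, tested at 0.5 uM, in the presence of a further agent that is not named here (a higher number here means a stronger effect of the compound at the concentration tested, a lower number a weaker effect), compound 1 gives 42.4%, the highest of the three numbers recorded. Compound 2 `C[C@@H]1CN(C(=O)c2nc(Nc3cc(C4CC4)[nH]n3)c3cc(Cl)ccc3n2)CCN1C(=O)OC(C)(C)C` carries tert-butyl, and in this assay compound 2 gives 0.1%. Compound 3 `C[C@@H]1CN(C(=O)c2nc(Nc3cc(C4CC4)[nH]n3)c3cc(Cl)ccc3n2)CCN1C(=O)OCc1ccccc1` carries benzyl, and in this assay compound 3 gives 4.4%. The steps of a number 42.3 percentage points lower from compound 1 to compound 2 (beyond the scatter) and a number 38 percentage points lower from compound 1 to compound 3 (beyond the scatter) are both large and both downward, whereas a number 4.3 percentage points higher from compound 2 to compound 3 (within the scatter) is within the scatter.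

Compound 4 `C[C@@H]1CN(C(=O)c2nc(Nc3cc(C4CC4)[nH]n3)c3cc(Cl)ccc3n2)CCN1C(=O)OCC(Cl)(Cl)Cl` is not yet measured. It differs from compound 1 in one place: trichloromethyl in place of methyl on a saturated chain carbon bound to an oxygen next to a carbonyl group. Both measured steps from compound 1 bear on this change, since in each the group on the oxygen next to a carbonyl group grows, and each time the number fell far. Trichloromethyl in place of methyl again grows that group, so a downward step beyond the scatter is expected in this assay, though no measured step matches this exact group and the size is uncertain. Compound 4 is therefore expected to give about 15%, within -5% to 40%. The expected step is a number 27.4 percentage points lower from compound 1 to compound 4 (beyond the scatter).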

Compound 4, a percentage reported as inhibition, at one concentration (the size of the read-out at that concentration, not a potency): -1.5%
Compound 4: the middle estimate sits 16.5 percentage points above what was measured; the measured number falls inside the stated range.
By their numbers in this assay, from the lowest: compounds 4, 2 and 3 (each within the scatter of the next); then compound 1.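

In this assay the change to 2,2,2-trichloroethyl gives a number 43.9 percentage points lower from compound 1 to compound 4 (beyond the scatter) and so behaves like the two earlier replacements of ethyl, while a number 5.9 percentage points lower from compound 3 to compound 4 (within the scatter) and a number 1.6 percentage points lower from compound 2 to compound 4 (within the scatter) leave compounds 2, 3 and 4 unseparated. The fall from compound 1 now occurs with a chlorine-bearing group with no ring as well as with the all-carbon tert-butyl and the ring-bearing benzyl, so across these four compounds it does not depend on the presence of a ring or on an all-carbon group, and ethyl is the only group shown that keeps a read-out clearly separated from the rest. Nothing measured here gives a reason for this fall.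

The compounds shown leave open how narrow the tolerance around ethyl is, since they do not tell whether methyl or n-propyl on the oxygen next to a carbonyl group would hold the read-out of compound 1, or whether 2,2,2-trifluoroethyl would follow the 2,2,2-trichloroethyl result. A chain ending in an amine or a carboxylic acid at this position also remains an open case.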